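A few compounds are considered here, and "the series" means these few. Any claim that something is new, unique, unknown or untested is made for them only; others in the source may bear on it.

In a functional assay for inhibition, with Homo sapiens as the target (on this read-out lower numbers stand for stronger inhibition and higher numbers for weaker inhibition), compound 1 `O=C(NC[C@H](NS(=O)(=O)c1cccnc1)C(=O)O)c1cc2cc(CCCC3CCNCC3)sc2s1` gives 21 nM and compound 2 `O=C(NC[C@H](NS(=O)(=O)c1ccc(Cl)cc1)C(=O)O)c1cc2cc(CCC3CCNCC3)sc2s1` gives 11 nM on closely related structures. These two numbers lie within the scatter of each other, so compound 2 stands level with compound 1 on the evidence so far. Compound 3 `O=C(NCc1ccccc1)N[C@@H](CNC(=O)c1cc2cc(CCC3CCNCC3)sc2s1)C(=O)O` has yet to be measured. The change from compound 2 to compound 3 is benzylcarbamoyl in place of (4-chlorophenyl)sulfonyl on an amine nitrogen and amounts to benzylcarbamoyl in place of (4-chlorophenyl)sulfonyl on an amine nitrogen. Among the measured compounds shown here, no measured pair shows a change at this place, so the data offer no direct guide to its size. In this assay the expectation is an estimated step of a 2.3-fold higher number from compound 2 to compound 3 (0.36 log units; beyond the scatter) towards weaker inhibition, only a little beyond the scatter. For compound 3 the expected value is 25 nM within an estimated range from 7 nM to 90 nM for this measurement.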

Compound 3, half-maximal inhibitory concentration: 76 nM
Compound 3: the middle estimate sits 3.0-fold (0.48 log units) below what was measured; the measured number falls inside the stated range.
By their numbers in this assay, from the lowest: compounds 2 and 1 (each within the scatter of the next); then compound 3.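

The first step read at this place shows that the group on the amine nitrogen is not a neutral choice: in this assay, benzylcarbamoyl in place of (4-chlorophenyl)sulfonyl gives a 6.9-fold higher number from compound 2 to compound 3 (0.84 log units; beyond the scatter), towards weaker inhibition. Both groups carry one six-membered aromatic ring of carbon only and the same number of heavy atoms, so a change of this size arises without any change in those two counts, although the exchange alters the link to the ring and removes the chlorine together. Nothing available explains the loss of inhibition.

Among the compounds shown here, the single step leaves the link and the chlorine unseparated. A 4-chlorobenzylcarbamoyl group or a benzylsulfonyl group on the same nitrogen would tell how much of the step belongs to each.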